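The compounds below may be only part of what the source reports. "The series", "measured", "known", "first", "only" and "open" are said of these compounds alone.

Of the compounds shown here, two have numbers so far in a functional assay on PC-3 cells (Homo sapiens) for cytotoxicity, read by MTT assay, with a stated time of 24 h; on this read-out lower numbers stand for stronger inhibition and higher numbers for weaker inhibition. Compound 1 `O=C1/C(=C/c2ccccc2F)CN(Cc2cn(Cc3cccc(Cl)c3)nn2)C/C1=C\c1ccccc1F` gives 6800 nM, and compound 2 `Cc1ccc(/C=C2\CN(C(=S)SCc3cn(Cc4ccc(F)cc4)nn3)C/C(=C\c3ccc(C)cc3)C2=O)cc1` gives 45500 nM. Compound 2 therefore stands at the higher of the two numbers, which means the weaker inhibition, and the gap lies beyond the usual scatter of repeated measurements. These two compounds differ in several places, so the gap cannot be tied to any single part of their structures.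

Compound 3 `Cc1ccc(/C=C2\CN(C(=S)SCc3cn(Cc4cccc(Cl)c4)nn3)C/C(=C\c3ccc(C)cc3)C2=O)cc1` is compound 2 with one change: 3-chlorophenyl in place of 4-fluorophenyl on a saturated chain carbon bound to an aromatic nitrogen. In words, 3-chlorophenyl sits in place of 4-fluorophenyl on a saturated chain carbon bound to an aromatic nitrogen. Among the measured compounds shown here, no measured pair shows this swap alone. For the measured compounds named here, the only hint comes from compound 1, which also carries the 3-chlorobenzyl group and gives 6800 nM, although the rest of its structure is different. The hint is weak, so only a small move towards a lower number is expected in this assay. The expected step of a 1.5-fold lower number from compound 2 to compound 3 (0.18 log units; within the scatter) may well stay within the scatter. For compound 3 the estimate is 30000 nM, with an expected range of 12000 nM to 70000 nM.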

Compound 3, half-maximal inhibitory concentration: > 80000 nM
Compound 3 ended at the assay's limit; the forecaster's own chance of this, stated with the estimate: 10%; middle value at least 2.6-fold (0.42 log units) away from the limit.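

In this assay, placing 3-chlorophenyl where 4-fluorophenyl stood, on a saturated chain carbon bound to an aromatic nitrogen, gives an at least 1.7-fold higher number from compound 2 to compound 3 (0.24 log units; that floor lies within the scatter). For compound 3, the reading of > 80000 nM is a limit of the assay and not a number: the limit of > 80000 nM in this assay, at which 1 of the 3 values shown sits. Among the compounds shown here, this is the first direct look at the change, and it shows that on the core shared by compound 2 and compound 3 the 3-chlorobenzyl group brings no lower number, although the floor of the step lies within the scatter, so a real rise is not established.

Compound 2 and compound 3 change both the halogen and the place it occupies on the ring, which leaves open which of these two differences matters in this pair. Going by these compounds, it also remains open how a 4-chlorobenzyl group, a 3-fluorobenzyl group or a plain benzyl group would read at this position on the same core in this assay, and whether any of them would give a number clear of the limit.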